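The source may report more compounds than this note shows. Statements on the series, on what has been measured and on what is new or still open speak of the compounds shown alone.

Working notes on the series. Compound 1 `Nc1nn(C(=O)Nc2ccc(Cc3ccccc3)cc2)c2ccccc12` and compound 2 `Nc1nn(C(=O)Nc2ccc(Cc3ccccc3)cc2)c2ccc(Cl)cc12` share one core and differ only by a chloro on an aromatic carbon in place of hydrogen. In a functional assay on SN12C cells (Homo sapiens) for antiproliferative activity, read by sulforhodamine B assay, with a stated time of 48 h (a higher number here means a weaker inhibitor of growth, a lower number a stronger inhibitor of growth), compound 1 gives 28000 nM, and compound 2 gives 42900 nM, a step of a 1.5-fold higher number from compound 1 to compound 2 (0.19 log units; within the scatter). Among the compounds with values here, compound 2 therefore holds the highest of the two numbers so far, with compound 1 the nearest, and the gap between them is within the scatter, so no order between the two can be read from it.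

Compound 3 `Nc1ccc2c(c1)c(N)nn2C(=O)Nc1ccc(Cc2ccccc2)cc1` is not yet measured. Relative to compound 2 the change is amino in place of chloro on an aromatic carbon. Within the data shown here, no measured step introduces an amino at this position; the only step in hand, from compound 1 to compound 2, concerns the chloro alone and was within the scatter. The change to compound 3 is thus without a direct precedent in the series, and the expectation in this assay is a step of a 1.3-fold lower number from compound 2 to compound 3 (0.13 log units; within the scatter), not beyond the scatter in either direction. For compound 3 the estimate is 32000 nM, with a range from 10000 nM to 100000 nM.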

Compound 3, concentration for total growth inhibition: 30900 nM
Estimate against measurement, compound 3: 1.0-fold (0.02 log units) above; measured number inside the range.
By their numbers in this assay, from the lowest: compounds 1, 3 and 2 (each within the scatter of the next).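

At this position, on an aromatic carbon of a six-membered aromatic ring of carbon only, the series now holds hydrogen, chloro and amino, and in this assay the change from chloro to amino gives a 1.4-fold lower number from compound 2 to compound 3 (0.14 log units; within the scatter) while the change from hydrogen to amino gives a 1.1-fold higher number from compound 1 to compound 3 (0.04 log units; within the scatter) and so both steps stay within the scatter. The earlier pair spoke for the chloro alone; with compound 3, a group that brings one hydrogen-bond donor and one hydrogen-bond acceptor where the chloro brings neither also leaves the read-out without a change that can be told from the scatter, so among these three compounds this carbon shows no sensitivity to the group it carries. Nothing at hand gives a reason for this.

From the compounds shown here alone, whether any group at this carbon can move the number beyond the scatter stays open, for instance a carboxylic acid, a methoxy or a longer chain such as an acetamide. Equally open, going by these compounds, is whether this flat picture holds for other aromatic carbons of the same ring, or for cell lines other than the one read here.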